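The source may report more compounds than this note shows. Statements on the series, on what has been measured and on what is new or still open speak of the compounds shown alone.

Working notes on the series. Among the measured compounds shown here, in a functional assay on PANC-1 cells (Homo sapiens) for inhibition, read by MTT assay, with a stated time of 24 h (on this read-out lower numbers stand for stronger inhibition and higher numbers for weaker inhibition), compound 1 (`CC1(C)[C@H]2CC[C@]1(C)N(Cc1cn(-c3ccccc3F)nn1)C(=O)C2`) gives 150 nM and compound 2 (`COc1ccccc1-n1cc(CN2C(=O)C[C@@H]3CC[C@@]2(C)C3(C)C)nn1`) gives 120 nM as the only two numbers so far. For the measured compounds named here, the single measured step (a 1.3-fold lower number from compound 1 to compound 2 (0.10 log units; within the scatter)) is methoxy in place of fluoro on an aromatic carbon, so compound 2 stands level with its one neighbour and the two cannot be ranked.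

Compound 3 (`CC1(C)[C@H]2CC[C@]1(C)N(Cc1cn(-c3ccc(O)cc3)nn1)C(=O)C2`) keeps the shared core and carries 4-hydroxyphenyl in place of 2-methoxyphenyl on an aromatic nitrogen. Going by the values given here, no measured compound has 4-hydroxyphenyl, so the data offer only indirect guidance. Among the compounds with values here, the one step on this aromatic ring (a 1.3-fold lower number from compound 1 to compound 2 (0.10 log units; within the scatter)) stayed small, and it is the only evidence on how far a change of this group moves the number. With compound 2 at 120 nM as the anchor, no step beyond the scatter is expected, although the untested group keeps the range wide in both directions. The expected change is small (a 1.4-fold higher number from compound 2 to compound 3 (0.15 log units; within the scatter)) and this estimate leans only slightly towards a higher number. In this assay compound 3 is expected at 170 nM (estimated range 60 nM to 500 nM).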

Compound 3, half-maximal inhibitory concentration: 100 nM
For compound 3 the middle estimate is 1.7-fold (0.23 log units) above the measured one; low and high end bracket the measured number.
By their numbers in this assay, from the lowest: compounds 3, 2 and 1 (each within the scatter of the next).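

In this assay, 4-hydroxyphenyl in place of 2-methoxyphenyl on the aromatic nitrogen gives a 1.2-fold lower number from compound 2 to compound 3 (0.08 log units; within the scatter), and 4-hydroxyphenyl in place of 2-fluorophenyl gives a 1.5-fold lower number from compound 1 to compound 3 (0.18 log units; within the scatter) as the second step at this position. Unlike the earlier fluoro-to-methoxy step, these steps change both the group on the phenyl ring and its place on that ring, and 4-hydroxyphenyl brings 1 hydrogen-bond donor where 2-methoxyphenyl has 0, yet neither step leaves the scatter, so compounds 1, 2 and 3 cannot be ranked. Thus, across these three aromatic groups, the position shows no measurable sensitivity to the changes, and no independent measurement is available to explain that result.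

The compounds shown do not separate the group from its place on the phenyl ring, which 2-hydroxyphenyl and 4-methoxyphenyl would do. Going by these compounds, it also remains open whether an amine or a carboxylic acid on the phenyl ring, or a longer chain in place of that ring, would produce a step beyond the scatter, and the shared core is unchanged throughout.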